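The compounds below may be only part of what the source reports. "The series", "measured", "known", "first", "only" and "open" are said of these compounds alone.

For the measured compounds named here, in an ADME assay on Vero 76 cells (Chlorocebus sabaeus) for cytotoxicity (a lower number here means that less compound is tolerated, a higher number that more compound is tolerated), compound 1 (`Nc1ncc(F)c2c1ncn2[C@@H]1C=C(CO)[C@@H](O)[C@H]1O`) gives 114000 nM while compound 2 (`Nc1ncc(F)c2c1ncn2[C@@H]1C=C(CCO)[C@@H](O)[C@H]1O`) gives 190000 nM and the two stand level, with a 1.7-fold higher number from compound 1 to compound 2 (0.22 log units; within the scatter) as the only measured step. Compound 3 (`Cc1cnc(N)c2ncn([C@@H]3C=C(CO)[C@@H](O)[C@H]3O)c12`) has methyl in place of fluoro on an aromatic carbon of the core of compound 1. The measured step lies elsewhere in the molecule and bears on this change only indirectly, so no step beyond the scatter is expected in this assay here. The step expected is a 1.1-fold higher number from compound 1 to compound 3 (0.02 log units; within the scatter) by this estimate. For compound 3 the estimated value is 120000 nM (expected range 45000 nM to 300000 nM).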

Compound 3, half-maximal cytotoxic concentration: 83300 nM
For compound 3 the middle estimate is 1.4-fold (0.16 log units) above the measured one; low and high end bracket the measured number.
By their numbers in this assay, from the lowest: compounds 3, 1 and 2 (each within the scatter of the next, the first and the last beyond it).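

At the aromatic carbon para to the amino group, methyl in place of fluoro leaves compound 3 level with compound 1 in this assay, with a 1.4-fold lower number from compound 1 to compound 3 (0.14 log units; within the scatter). For the compounds shown here, the only earlier step lay in the chain on the double-bonded ring carbon, so this is the first sign that this change on the shared core also stays within the scatter. No measured evidence bears on the reason for this result. The compounds shown leave open whether an amine, a nitrile or a longer chain on this aromatic carbon would also stay within the scatter of compound 1.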